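The source may hold more compounds than are shown below. What is called first, only, known or untested is meant among the compounds shown, and "the series" means these compounds.

Compound 1 `CC(C)C(Cc1nnc[nH]1)c1ccc(-c2ccc3cccc(F)c3c2)[nH]c1=O` gives 0.307 h in an ADME assay on microsomes from liver (Homo sapiens) for metabolic stability; a higher number here means that the compound lasts longer, a lower number that the compound disappears faster. Of the two plain numbers in hand it stands lowest; compound 3 `CCn1ncc2c(F)cc(-c3ccc(C(CC)(CC)c4nncn4C)c(=O)[nH]3)cc21` gives 2.67 h in this assay, a clearly higher number, beyond the scatter. Compound 2 `CCn1ncc2c(F)cc(-c3ccc(C(CC)(CC)c4nnc(C)[nH]4)c(=O)[nH]3)cc21` gives in this assay only a limit of the assay, > 3 h, as the limit of > 3 h in this assay, at which 1 of the 3 values shown sits, records. For the measured compounds named here, the single step measured between two compounds that differ in one place runs an at least 1.1-fold lower number from compound 2 to compound 3 (0.05 log units; that floor lies within the scatter).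

Compound 4 `CC(C)C(Cc1nnn[nH]1)c1ccc(-c2ccc3cccc(F)c3c2)[nH]c1=O` is not yet measured. It differs from compound 1 by 1H-tetrazol-5-yl in place of 4H-1,2,4-triazol-3-yl on a saturated chain carbon, two bonds along the chain from an aromatic carbon. Going by the values given here, no measured pair swaps the five-membered aromatic ring itself; the step from compound 2 to compound 3 only moves the methyl, from 5-methyl-4H-1,2,4-triazol-3-yl to 4-methyl-4H-1,2,4-triazol-3-yl, and stayed within the scatter, so it gives at most a loose analogy. The expectation is therefore no step beyond the scatter in this assay, written as a 1.1-fold higher number from compound 1 to compound 4 (0.06 log units; within the scatter). Compound 4 is estimated at 0.35 h, with a range from 0.15 h to 0.9 h.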

Compound 4, half-life: > 3 h
Compound 4: no number, only a limit; the forecaster's own chance of this, stated with the estimate: 2%; middle value at least 8.5-fold (0.93 log units) from the limit.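

Replacing 4H-1,2,4-triazol-3-yl with 1H-tetrazol-5-yl, on a saturated chain carbon two bonds along the chain from an aromatic carbon, gives in this assay an at least 9.7-fold higher number from compound 1 to compound 4 (0.98 log units; beyond the scatter). The earlier step, an at least 1.1-fold lower number from compound 2 to compound 3 (0.05 log units; that floor lies within the scatter), only moved a methyl on the ring, whereas this change alters the five-membered aromatic ring itself, from 3 to 4 hetero atoms, with 5 heavy atoms on either side. Compound 4 gives only a limit of the assay, so the step is a floor and not a full size: the limit of > 3 h in this assay, at which 2 of the 4 values shown sit.

From the compounds shown here alone, how far the number rises beyond that floor stays open, as does whether the same exchange carries over to the core of compound 3. Also open, going by these compounds, is whether a carboxylic acid on the same chain carbon would read like 1H-tetrazol-5-yl or like 4H-1,2,4-triazol-3-yl.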